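Sulfonyl-to-carbonyl swap on the indole acrylonitrile series

The compounds below may be only part of what the source reports. "The series", "measured", "known", "first", "only" and "open" are said of these compounds alone.

Measured compounds:
compound 1 `COc1ccc(-c2[nH]c3ccccc3c2/C=C(\C#N)S(=O)(=O)c2ccccc2)cc1` 450 nM
compound 2 `CC(=O)/C(=C\c1c(-c2ccccc2)[nH]c2ccccc12)S(=O)(=O)c1ccccc1` 3000 nM
compound 3 `N#C/C(=C\c1c(-c2ccccc2)[nH]c2ccccc12)S(=O)(=O)c1ccccc1` 2900 nM

In a functional assay on DU-145 cells (Homo sapiens) for inhibition, read by sulforhodamine B assay, with a stated time of 48 h (a lower number here means a stronger inhibitor of growth, a higher number a weaker inhibitor of growth), compound 3 stands second highest of the three numbers, within the scatter of compound 2 and well apart from compound 1. The step to compound 4 `N#C/C(=C\c1c(-c2ccccc2)[nH]c2ccccc12)C(=O)c1ccccc1` is benzoyl in place of phenylsulfonyl on a double-bonded chain carbon bound to a double-bonded chain carbon and a triple-bonded carbon. Within the data shown here, no measured step touches this position directly. The step of a 1.0-fold lower number from compound 2 to compound 3 (0.01 log units; within the scatter) changed the other group on the same chain carbon and was flat; the step of a 6.4-fold higher number from compound 1 to compound 3 (0.81 log units; beyond the scatter) concerned a distant aromatic substituent and does not inform this change. Among the measured compounds shown here, with no direct precedent, no step beyond the scatter is expected in this assay, and compound 4 is estimated at 3000 nM (range 800 nM to 12000 nM), meaning an expected step of a 1.0-fold higher number from compound 3 to compound 4 (0.01 log units; within the scatter).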

Compound 4, concentration for 50% growth inhibition: 5200 nM
Compound 4: the middle estimate sits 1.7-fold (0.24 log units) below what was measured; measured number inside the range.
By their numbers in this assay, from the lowest: compound 1; then compounds 3, 2 and 4 (each within the scatter of the next).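

In this assay, benzoyl in place of phenylsulfonyl gives a 1.8-fold higher number from compound 3 to compound 4 (0.25 log units; within the scatter). Among these compounds, this is the first direct reading at this position, and it shows that, for this pair, the phenylsulfonyl group can be exchanged for benzoyl without a step beyond the scatter. No measurement on hand gives a cause for this result. Still open, as far as these compounds go, is how a carboxamide or a methyl ester would read on the same chain carbon. Also open, from the compounds shown here alone, is whether the methoxy that separates compound 1 from compound 3 would count the same way alongside benzoyl.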